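A few compounds are considered here, and "the series" means these few. Any claim that something is new, unique, unknown or untested is made for them only; others in the source may bear on it.

In a functional assay on EA.hy 926 cells (Homo sapiens) for cytotoxicity, read by MTT assay, with stated times of 24 h and 12 h (a lower number here means that less compound is needed, a higher number that more compound is needed for the effect), compound 3 (`Cc1nc(C)c(C(=O)Oc2ccc(/C=C/C(=O)O)cc2)nc1C`) gives 38000 nM. Compound 1 (`COc1cc(/C=C/C(=O)O)ccc1OC(=O)c1nc(C)c(C)nc1C`) gives 69400 nM, which is within the scatter of compound 3, while compound 2 (`CCOC(=O)/C=C/c1ccc(OC(=O)c2nc(C)c(C)nc2C)c(O)c1`) gives a clearly lower number at 1700 nM.

The next change leads to compound 4 (`Cc1nc(C)c(C(=O)Oc2ccc(/C=C/C(=O)O)cc2O)nc1C`), with hydroxy in place of hydrogen on an aromatic carbon.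

Two pieces of evidence bear on this change. Going by the values given here, the only measured step at this carbon is a 1.8-fold lower number from compound 1 to compound 3 (0.26 log units; within the scatter), so exchanging methoxy for hydrogen there did not move the number beyond the scatter. That step says nothing directly about hydroxy. Compound 2 does carry hydroxy at this carbon, and its value of 1700 nM suggests that the group is compatible with a low number. However, compound 2 also has an ethyl ester where compound 3 has the free acid, and no measured pair separates these two differences. Only a small part of the gap is therefore credited to hydroxy, and a modest move to a lower number is expected in this assay.

The expected change is a 2.4-fold lower number from compound 3 to compound 4 (0.38 log units; beyond the scatter), close to the edge of the scatter. For compound 4, the estimated value is 16000 nM, with an expected range from 4000 nM to 45000 nM.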

Compound 4, half-maximal effective concentration: 2200 nM
Beside the measured number, compound 4's estimate is 7.3-fold (0.86 log units) above it; measured number outside the range, below it.
By their numbers in this assay, from the lowest: compounds 2 and 4 (each within the scatter of the next); then compounds 3 and 1 (each within the scatter of the next).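

In this assay, hydroxy at this aromatic carbon brings a 17-fold lower number from compound 3 to compound 4 (1.24 log units; beyond the scatter) and so accounts for a large move that the earlier compounds could not separate from the ester. Among the three groups seen at this carbon, hydroxy alone stands apart: methoxy against hydrogen gives only a 1.8-fold lower number from compound 1 to compound 3 (0.26 log units; within the scatter) within the series, while removing the methyl from that oxygen gives a 32-fold lower number from compound 1 to compound 4 (1.50 log units; beyond the scatter) with the free acid kept in both compounds. With hydroxy present, the free acid and the ethyl ester are not told apart, as a 1.3-fold higher number from compound 2 to compound 4 (0.11 log units; within the scatter) stays within the scatter, so the low number of compound 2 does not depend on the ethyl group.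

Still open, as far as these compounds go, is whether an amine or a fluorine at this carbon would match hydroxy, whether a longer chain on the ester oxygen would hold the low number, and whether acid and ethyl ester also match in a compound without hydroxy. No measurement shown here gives a reason for the size of the hydroxy step.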